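From an Amide Ring to a Nitrile Ring

A few compounds are considered here, and "the series" means these few. Any claim that something is new, unique, unknown or untested is made for them only; others in the source may bear on it.

- compound 1 `COC(=O)C1=C(C)N=C(C)/C(=C(/O)OC)C1c1ccccc1OCc1nonc1C(N)=O` at 970 nM
- compound 2 `COC(=O)C1=C(C)N=C(C)/C(=C(/O)OC)C1c1cccc(OCc2c(C#N)no[n+]2[O-])c1` at 11 nM

Both numbers come from a functional assay (aorta) with Rattus norvegicus as the target, in the presence of a further agent that is not named here (on this read-out lower numbers stand for an effect already at smaller amounts and higher numbers for an effect only at larger amounts of compound), and are the only two available so far. Compound 1 has the higher number, 970 nM, so it needs the larger amount to act, and the gap down to compound 2 lies beyond the usual scatter.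

Compound 3 `COC(=O)C1=C(C)N=C(C)/C(=C(/O)OC)C1c1ccccc1OCc1no[n+]([O-])c1C#N` keeps the core of compound 1 and differs in one place, a group of 8 heavy atoms (3 carbon, 3 nitrogen, 2 oxygen; one five-membered aromatic ring with 3 hetero atoms) in place of a group of 8 heavy atoms (3 carbon, 3 nitrogen, 2 oxygen; one five-membered aromatic ring with 3 hetero atoms), on a saturated chain carbon bound to an oxygen on an aromatic ring (the 4-carbamoyl-1,2,5-oxadiazol-3-yl group leaves, and the entering group has a triple bond outside aromatic rings and no hydrogen-bond donors). Among the compounds with values here, no measured pair shows this swap alone, so the only guide is loose. Compound 2 also carries a nitrile on its ring and gives 11 nM, but it differs from compound 3 in more than one place. The expected step of a 16-fold lower number from compound 1 to compound 3 (1.21 log units; beyond the scatter) runs towards a lower number, beyond the scatter. The estimated value for compound 3 is 60 nM, with an expected range of 10 nM to 400 nM in this assay.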

Compound 3, half-maximal effective concentration: 4.4 nM
Compound 3: the middle estimate sits 14-fold (1.13 log units) above what was measured; the whole stated range lies above it.
By their numbers in this assay, from the lowest: compound 3; then compound 2; then compound 1.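

In this assay the swap at this position, on a saturated chain carbon bound to an oxygen on an aromatic ring, gives a 220-fold lower number from compound 1 to compound 3 (2.34 log units; beyond the scatter) and so moves the number far beyond the usual scatter. Within the data shown here, this is the first pair that differs in one place only, and it shows that this position strongly affects the read-out even when the core stays the same and the leaving and entering groups have the same count of heavy atoms of each element. The counted differences are that the entering group has a triple bond outside aromatic rings and no hydrogen-bond donors, but no measurement here connects the step to either feature or explains it.

On these data alone, it remains open whether the nitrile itself carries the step or whether other differences between the two groups also contribute, which a carboxylic acid or an amine on the same ring could help to separate. As far as these compounds go, it is also open how the number would respond to a longer chain between the oxygen and the five-membered ring.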